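The compounds below may be only part of what the source reports. "The series", "measured", "known", "first", "only" and "open" are said of these compounds alone.

Compound 3 `CCCCCCCCCCCCCCNC(=O)[C@@H](NC(=O)c1cc2ccccc2[nH]1)[C@@H](C)O` gives the lowest number of the three measured in a functional assay on MCF7 cells (Homo sapiens) for cytotoxicity, read by MTT assay, with a stated time of 48 h (a higher number here means a weaker inhibitor, a lower number a stronger inhibitor), at 15100 nM; compound 2 `CCCCCCCCCCCCCCNC(=O)[C@@H](NC(=O)c1cccs1)[C@@H](C)O` gives 36100 nM and compound 1 `CCCCCCCCCCCCCCNC(=O)[C@@H](NC(=O)c1ccco1)[C@@H](C)O` gives 105000 nM. The measured steps were a 2.9-fold lower number from compound 1 to compound 2 (0.46 log units; beyond the scatter), a 2.4-fold lower number from compound 2 to compound 3 (0.38 log units; beyond the scatter) and a 7.0-fold lower number from compound 1 to compound 3 (0.84 log units; beyond the scatter), each a swap of one aromatic group for another on the carbonyl carbon. Compound 4 `C/C=C/C=C/C(=O)N[C@H](C(=O)NCCCCCCCCCCCCCC)[C@@H](C)O` differs from compound 3 by penta-1,3-dien-1-yl in place of 1H-indol-2-yl on a carbonyl carbon. Among the measured compounds shown here, no measured step removes the ring altogether, so the bearing of those steps is indirect; since the smallest aromatic group, in compound 1, gave the highest number, a rise in this assay is expected, of about a 4.0-fold higher number from compound 3 to compound 4 (0.60 log units; beyond the scatter). Compound 4 is therefore estimated at 60000 nM, within 15000 nM to 250000 nM.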

Compound 4, half-maximal inhibitory concentration: 27800 nM
Estimate against measurement, compound 4: 2.2-fold (0.33 log units) above, within the range that was stated.
By their numbers in this assay, from the lowest: compounds 3, 4 and 2 (each within the scatter of the next, the first and the last beyond it); then compound 1.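

In this assay, a ring on the carbonyl carbon proves not to be required among these compounds: penta-1,3-dien-1-yl, which has no ring, gives a 1.8-fold higher number from compound 3 to compound 4 (0.27 log units; within the scatter) and a 1.3-fold lower number from compound 2 to compound 4 (0.11 log units; within the scatter), so it cannot be told apart from 1H-indol-2-yl or thiophen-2-yl. It still gives a 3.8-fold lower number from compound 1 to compound 4 (0.58 log units; beyond the scatter), so compound 1 alone stays apart from compound 4. Nothing available explains this result. Open, on these data alone, is whether a saturated pentyl chain in this place would match compound 4, which would show whether the double bonds matter, and how a phenyl ring would compare.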